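This account rests on a few compounds, and the source may have more. Where it says the series, first, only, none or still open, it means among the compounds named here.

The series shares one core, seen in compound 1 `COc1cc2c(Nc3nc4ccc(C(=O)Nc5c(C)cc(C)cc5C)cc4s3)ncnc2cc1OCCCN1CCC(C)CC1`. In a functional assay on DLD-1 cells (Homo sapiens) for cytotoxicity, read by WST assay, with a stated time of 72 h (a higher number here means a weaker inhibitor, a lower number a stronger inhibitor), compound 1 gives 7000 nM. Within the data shown here, compound 3 `CCN(CC)CCCOc1cc2ncnc(Nc3nc4ccc(C(=O)Nc5c(C)cc(C)cc5C)cc4s3)c2cc1OC` gives 6800 nM in this assay; the only step measured in one place, a 1.0-fold lower number from compound 1 to compound 3 (0.01 log units; within the scatter), leaves the number as it was. Compound 2 `COc1cc2c(Nc3nc4ccc(C(=O)Nc5c(C)cccc5C)cc4s3)ncnc2cc1OCCCN1CCCC1` differs from compound 1 in two places, one of them the aryl group on the amide-type nitrogen. In this assay compound 2 gives only a limit of the assay, > 100000 nM. That limit is the limit of > 100000 nM in this assay, at which 1 of the 3 values shown sits. Of the two numbers shown, compound 1 and compound 3 sit within the scatter of each other, so neither stands apart.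

Compound 4 `COc1cc2c(Nc3nc4ccc(C(=O)Nc5c(C)cccc5Cl)cc4s3)ncnc2cc1OCCCN1CCC(C)CC1` differs from compound 1 in one place: 2-chloro-6-methylphenyl in place of 2,4,6-trimethylphenyl on an amide-type nitrogen. Among the measured compounds shown here, no measured step touches this group on its own; the single one-place step, a 1.0-fold lower number from compound 1 to compound 3 (0.01 log units; within the scatter), concerns the amine on the chain and was within the scatter. What compound 1 and compound 2 show together is that a pair of changes including the aryl group on the amide-type nitrogen ended at the limit. The step expected here, a 4.3-fold higher number from compound 1 to compound 4 (0.63 log units; beyond the scatter), is therefore towards a weaker number for compound 4, with wide uncertainty. Compound 4 is estimated at 30000 nM, between 7000 nM and 100000 nM, in this assay.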

Compound 4, half-maximal inhibitory concentration: 11300 nM
Beside the measured number, compound 4's estimate is 2.7-fold (0.42 log units) above it, within the range that was stated.
By their numbers in this assay, from the lowest: compounds 3, 1 and 4 (each within the scatter of the next). At a limit, above all of these: compound 2.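

The aryl group on the amide-type nitrogen now has a measured step of its own: in this assay, 2-chloro-6-methylphenyl in place of 2,4,6-trimethylphenyl gives a 1.6-fold higher number from compound 1 to compound 4 (0.21 log units; within the scatter). With the 4-methylpiperidin-1-yl chain held constant, this exchange leaves the number as it was, as the amine exchange on the chain did in a 1.0-fold lower number from compound 1 to compound 3 (0.01 log units; within the scatter), and it alters the aryl group at two points at once, so the step cannot be divided between the lost methyl groups and the entering chlorine. Nothing shown gives a reason why these two aryl groups read alike.

Compound 2 gives > 100000 nM, a limit of the assay, and with two places changed from compound 1, the steps shown do not assign that limit to either change. Also open, from the compounds shown here alone, is how this assay reads an unsubstituted phenyl or a 2,6-dichlorophenyl on the amide-type nitrogen, or a morpholine at the end of the chain, each set on the core of compound 1.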